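The source may report more compounds than this note shows. Statements on the series, on what has been measured and on what is new or still open speak of the compounds shown alone.

Measured compounds:
Compound 1 `COC1=CC(=O)C(=O)C(CCCCCCCCO)=C1OC` — in an assay on isolated protein for inhibition of Polyunsaturated fatty acid 5-lipoxygenase (Homo sapiens), read by HPLC, with stated times of 15 min and 10 min (on this read-out higher numbers stand for weaker inhibition and lower numbers for stronger inhibition), compound 1 gives 150 nM.
Compound 2 `COC1=CC(=O)C(=O)C(CCCCCCCCCCO)=C1OC` — in this assay compound 2 gives 360 nM.

Compound 2 holds the highest number of the two measured in this assay; its nearest neighbour is compound 1, and the step between them is a 2.4-fold higher number from compound 1 to compound 2 (0.38 log units; beyond the scatter). Compound 3 `COC1=CC(=O)C(=O)C(CCCCCCCCCCCO)=C1OC` has not yet been measured. It differs from compound 2 by hydroxymethyl in place of hydroxy on a saturated chain carbon, ten or more bonds along the chain from a double-bonded ring carbon. Among the measured compounds shown here, the one measured step that bears on this change is the lengthening of the same chain by one carbon, a 2.4-fold higher number from compound 1 to compound 2 (0.38 log units; beyond the scatter), which was modest and beyond the scatter. A further lengthening of the chain is therefore expected to move the number in the same direction, by a modest amount, with a 1.8-fold higher number from compound 2 to compound 3 (0.26 log units; within the scatter) as the expected step. Compound 3 is estimated at 650 nM in this assay, within a range from 300 nM to 1500 nM.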

Compound 3, half-maximal inhibitory concentration: 120 nM
Compound 3: the middle estimate sits 5.4-fold (0.73 log units) above what was measured, and the stated range ends above it.
By their numbers in this assay, from the lowest: compounds 3 and 1 (each within the scatter of the next); then compound 2.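

In this assay, hydroxymethyl in place of hydroxy at this place, on a saturated chain carbon, turns the number back (a 3.0-fold lower number from compound 2 to compound 3 (0.48 log units; beyond the scatter)), the opposite direction to the earlier lengthening (a 2.4-fold higher number from compound 1 to compound 2 (0.38 log units; beyond the scatter)). Across these three compounds the number therefore does not follow chain length in one direction, and compound 3 with the longest chain stands level with compound 1 with the shortest (a 1.3-fold lower number from compound 1 to compound 3 (0.10 log units; within the scatter)). Nothing on hand accounts for this turn. What the compounds shown leave open is whether a still longer chain would continue the fall or reverse it. They also leave open how a carboxylic acid or an amine at the chain end would compare with the hydroxy group.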